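A few compounds are considered here, and "the series" means these few. Any claim that something is new, unique, unknown or untested is made for them only; others in the source may bear on it.

Compound 1 (`C/C=C/C(=O)N(Cc1ccc(OC)c(OC)c1)c1cc(OC)c(OC)c(OC)c1`) and compound 2 (`C/C=C/C(=O)N(Cc1cccc(O)c1)c1cc(OC)c(OC)c(OC)c1`) share one core and differ in the ring-bearing group on a saturated chain carbon bound to an amide-type nitrogen. In a functional assay on MGC-803 cells (Homo sapiens) for inhibition, read by MTT assay, with a stated time of 48 h (on this read-out lower numbers stand for stronger inhibition and higher numbers for weaker inhibition), compound 1 gives 20100 nM and compound 2 gives 14100 nM. These two values lie within the scatter of each other, so compound 2 stands level with compound 1 and neither can be ranked over the other.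

Compound 3 (`C/C=C/C(=O)N(Cc1ccc(OC)c(F)c1)c1cc(OC)c(OC)c(OC)c1`) departs from compound 2 at that same place, with 3-fluoro-4-methoxyphenyl in place of 3-hydroxyphenyl on a saturated chain carbon bound to an amide-type nitrogen. Within the data shown here, no measured step yet shows what this exchange does on its own. The nearest guide is compound 1, whose ring also carries a methoxy group and whose value of 20100 nM gives no separation from compound 2. On that basis, no change beyond the scatter is expected. The expected step is a 1.1-fold lower number from compound 2 to compound 3 (0.04 log units; within the scatter), an estimate that stays within the usual scatter. In this assay, compound 3 is estimated at 13000 nM, with an expected range of 5000 nM to 32000 nM.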

Compound 3, half-maximal inhibitory concentration: 1650 nM
The estimate for compound 3 lay 7.9-fold (0.90 log units) above the measured number, and the stated range ends above it.
By their numbers in this assay, from the lowest: compound 3; then compounds 2 and 1 (each within the scatter of the next).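

In this assay, the ring-bearing group on a saturated chain carbon bound to an amide-type nitrogen proves able to move the number well beyond the scatter, which compounds 1 and 2 had not shown: 3-fluoro-4-methoxyphenyl in place of 3-hydroxyphenyl gives an 8.5-fold lower number from compound 2 to compound 3 (0.93 log units; beyond the scatter) at this place. The sharper reading comes from the closer pair, where fluoro in place of methoxy on an aromatic carbon gives a 12-fold lower number from compound 1 to compound 3 (1.09 log units; beyond the scatter) and so shows that this single ring exchange is enough for a large step, with the rest of compound 1 unchanged. No experimental evidence is given here to account for the size of either step.

The compounds shown leave open whether fluoro is itself needed at this place, or whether chloro, a nitrile or trifluoromethyl in its stead would give a similar number. They also leave open what the methoxy group of the 3-fluoro-4-methoxyphenyl ring adds, and whether an amine or a carboxylic acid on that ring would be tolerated on the shared core.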